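Hydroxamic acid stilbenes: cap ring swap on the pyridine

This account rests on a few compounds, and the source may have more. Where it says the series, first, only, none or still open, it means among the compounds named here.

Three members of the series have numbers in a functional assay on MGC-803 cells (Homo sapiens) for antiproliferative activity, read by CellTiter-Glo, with a stated time of 72 h; on this read-out higher numbers stand for weaker inhibition and lower numbers for stronger inhibition. Compound 1 `O=C(NO)c1ccc(/C=C/c2ccnc(-c3cccc(O)c3)c2)cc1` gives 2100 nM in this assay and holds the lower of the two numbers shown. Compound 3 `Cc1ccc(-c2cc(/C=C/c3ccc(C(=O)NO)cc3)c(F)cn2)c(F)c1` gives 2510 nM in this assay, a value that sits within the usual scatter of that of compound 1, so no order between the two is claimed. Compound 2 `O=C(NO)c1ccc(/C=C/c2cccc(-c3cc(F)ccc3O)c2)cc1` reaches only the limit of this assay, > 10000 nM, and is reported as a limit rather than as a number; of the three values one sits there (the limit of > 10000 nM in this assay, at which 1 of the 3 values shown sits).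

Compound 4 `O=C(NO)c1ccc(/C=C/c2ccnc(-c3ccsc3)c2)cc1` has not yet been measured in this assay. It differs from compound 1 in one place: thiophen-3-yl in place of 3-hydroxyphenyl on an aromatic carbon. Among the compounds with values here, no measured pair isolates this change, so its size can only be estimated from the compounds in hand. The hydroxamic acid and the stilbene linker are kept, and the change is confined to the cap ring; a small step toward weaker inhibition, at the edge of the scatter, is expected from compound 1 to compound 4, a 1.5-fold higher number from compound 1 to compound 4 (0.18 log units; within the scatter). Compound 4 is accordingly estimated at 3200 nM in this assay, with a range from 1200 nM to 8500 nM.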

Compound 4, half-maximal inhibitory concentration: 3680 nM
For compound 4 the middle estimate is 1.2-fold (0.06 log units) below the measured one; the measured number falls inside the stated range.
By their numbers in this assay, from the lowest: compounds 1, 3 and 4 (each within the scatter of the next). At a limit, above all of these: compound 2.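

In this assay, this pair gives the series its first direct reading of a cap ring change at this position, on an aromatic carbon next to the ring nitrogen: a 1.8-fold higher number from compound 1 to compound 4 (0.24 log units; within the scatter). The step is within the scatter, so in this pair, thiophen-3-yl and 3-hydroxyphenyl cannot be told apart, even though the five-membered ring with its sulfur has no hydrogen-bond donor and the six-membered carbon ring has one. The hydrogen-bond donor of 3-hydroxyphenyl is therefore not needed to hold the number in this range on the core of compound 1, and nothing measured here bears on the reason for the size of this step.

On these data alone, what a cap ring carrying an amine or a carboxylic acid would do at this position remains open, as does whether any replacement of 3-hydroxyphenyl there can move the number beyond the scatter in either direction. Within the data shown here, compound 2 gives > 10000 nM, which is a limit and not a number, and it differs from compound 1 in more than one place, so no step to it can be read.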